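The source may report more compounds than this note shows. Statements on the series, on what has been measured and on what is new or still open speak of the compounds shown alone.

Compound 1 `CN1CCN(c2ccc(Nc3ncc(Cl)c(NCc4ccc(F)cc4)n3)nc2)CC1`: > 100000 nM, a limit
Compound 2 `CCc1ccc(Nc2nc(Nc3ccc(N4CCN(C)CC4)cn3)ncc2Cl)cc1`: 5560 nM
Compound 3 `CC(C)c1cccc(Nc2nc(Nc3ccc(N4CCN(C)CC4)cn3)ncc2Cl)c1`: 5590 nM

In a functional assay on MDA-MB-231 cells (Homo sapiens) for inhibition, read by CCK-8 assay, with a stated time of 48 h (on this read-out higher numbers stand for weaker inhibition of growth and lower numbers for stronger inhibition of growth), compound 3 gives 5590 nM, and the nearest measured gap is a 1.0-fold higher number from compound 2 to compound 3 (0.00 log units; within the scatter). Compound 1 stands at the limit of > 100000 nM in this assay, at which 1 of the 3 values shown sits. Compound 4 `COc1ccc(Nc2nc(Nc3ccc(N4CCN(C)CC4)cn3)ncc2Cl)cc1` differs from compound 3 as follows: 4-methoxyphenyl in place of 3-isopropylphenyl on a nitrogen on an aromatic ring. In words, 4-methoxyphenyl stands in place of 3-isopropylphenyl on a nitrogen on an aromatic ring. The large steps of an at least 17-fold lower number from compound 1 to compound 2 (1.25 log units; beyond the scatter) and an at least 17-fold lower number from compound 1 to compound 3 (1.25 log units; beyond the scatter) both remove 4-fluorobenzyl, a change not made here. For the measured compounds named here, the closest precedent is a 1.0-fold higher number from compound 2 to compound 3 (0.00 log units; within the scatter), which also exchanges one substituted phenyl for another, so no step beyond the scatter is expected. The expected step is a 1.1-fold higher number from compound 3 to compound 4 (0.03 log units; within the scatter). Compound 4 is estimated at 6000 nM, with an expected range from 2500 nM to 15000 nM.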

Compound 4, concentration for 50% growth inhibition: 8020 nM
Beside the measured number, compound 4's estimate is 1.3-fold (0.13 log units) below it, within the range that was stated.
By their numbers in this assay, from the lowest: compounds 2, 3 and 4 (each within the scatter of the next). At a limit, above all of these: compound 1.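

Among the compounds shown, only compound 4 carries a hydrogen-bond acceptor in the group on this nitrogen, yet in this assay this exchange stays within the scatter (a 1.4-fold higher number from compound 3 to compound 4 (0.16 log units; within the scatter)), as does methoxy in place of ethyl (a 1.4-fold higher number from compound 2 to compound 4 (0.16 log units; within the scatter)). The large gap to the 4-fluorobenzyl compound holds for 4-methoxyphenyl too (an at least 12-fold lower number from compound 1 to compound 4 (1.09 log units; beyond the scatter)). Compound 1 remains a limit, not a number: the limit of > 100000 nM in this assay, at which 1 of the 4 values shown sits.

From the compounds shown here alone, what an amine, a carboxylic acid or a longer chain on this phenyl ring would give stays open. So does whether any substituent there moves the number beyond the scatter.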